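This account rests on a few compounds, and the source may have more. Where it says the series, first, only, none or still open, it means among the compounds named here.

Measured so far in a physicochemical assay for lipophilicity; a higher number here means a more lipophilic compound, a lower number a more polar compound
- Compound 1 `Cc1ccccc1C1C[C@@]2(ON1c1ccccc1)C(=O)O[C@@H]1[C@H]2CC[C@H](C)[C@]2(O)C=CC(=O)[C@@]12C` gives 3.64
- Compound 2 `C[C@H]1CC[C@@H]2[C@@H](OC(=O)[C@]23CC(c2ccccc2F)N(c2ccccc2)O3)[C@]2(C)C(=O)C=C[C@@]12O` gives 3.35

Compound 2 at 3.35 sits within the scatter of compound 1 at 3.64 and the two cannot be ranked. Compound 3 `C[C@H]1CC[C@@H]2[C@@H](OC(=O)[C@]23CC(c2c(F)c(F)c(F)c(F)c2F)N(c2ccccc2)O3)[C@]2(C)C(=O)C=C[C@@]12O` has not been measured. It carries 2,3,4,5,6-pentafluorophenyl in place of 2-fluorophenyl on a saturated ring carbon. Going by the values given here, the one measured step (a number 0.29 log units lower from compound 1 to compound 2 (within the scatter)) lies within the scatter and swaps fluoro for methyl on an aromatic carbon, so it is only a loose guide to this larger change. A modest upward step is expected (a number 0.40 log units higher from compound 2 to compound 3 (beyond the scatter)). Compound 3 is estimated at 3.75 in this assay, with a range from 3.35 to 4.2 as expected limits of that estimate.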

Compound 3, partition coefficient: 3.72
Estimate against measurement, compound 3: 0.03 log units above, and the stated range covers the measured number.
By their numbers in this assay, from the lowest: compounds 2, 1 and 3 (each within the scatter of the next, the first and the last beyond it).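

In this assay, going by these compounds alone, 2,3,4,5,6-pentafluorophenyl in place of 2-fluorophenyl on the saturated ring carbon gives a number 0.37 log units higher from compound 2 to compound 3 (beyond the scatter) and is the first step at this position to clear the scatter. In place of 2-methylphenyl, the same group gives a number 0.08 log units higher from compound 1 to compound 3 (within the scatter) and so sets no order between those two. Nothing available accounts for the size of either step. Open, as far as these compounds go, is how a difluorophenyl or trifluorophenyl ring would compare at this carbon, and whether a pyridine ring or a phenyl ring bearing a carboxylic acid would shift the number.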